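Cyclopentyl to 1-(hydroxymethyl)ethyl on the shared core

The source may report more compounds than this note shows. Statements on the series, on what has been measured and on what is new or still open speak of the compounds shown alone.

- compound 1 `CC(C)Oc1cc(Oc2cnc(C(=O)N(C)C)nc2)cc(-c2nccc(=O)[nH]2)c1` gives 332000 nM here
- compound 2 `CN(C)C(=O)c1ncc(Oc2cc(OC3CCCC3)cc(-c3nccc(=O)[nH]3)c2)cn1` gives 398000 nM here

Both values come from a physicochemical assay for solubility, in phosphate buffer, measured as kinetic solubility, with a stated time of 24 h, at pH 6.5 (a higher number here means a more soluble compound, a lower number a less soluble compound), and lie within the scatter of each other, so compound 2 stands level with compound 1. Compound 3 `C[C@@H](CO)Oc1cc(Oc2cnc(C(=O)N(C)C)nc2)cc(-c2nccc(=O)[nH]2)c1` has 1-(hydroxymethyl)ethyl in place of cyclopentyl on an oxygen on an aromatic ring. Within the data shown here, one measured step bears on this, a 1.2-fold higher number from compound 1 to compound 2 (0.08 log units; within the scatter), which changed the group in the same place and stayed within the scatter. Among the measured compounds shown here, no measured step brings in a group of this kind, so the expectation is weakly supported. The step expected is a 1.0-fold lower number from compound 2 to compound 3 (0.02 log units; within the scatter), nothing beyond the scatter. For compound 3 the estimated value is 380000 nM (range 190000 nM to 700000 nM).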

Compound 3, solubility: 339000 nM
Beside the measured number, compound 3's estimate is 1.1-fold (0.05 log units) above it; low and high end bracket the measured number.
By their numbers in this assay, from the lowest: compounds 1, 3 and 2 (each within the scatter of the next).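

In this assay the swap to 1-(hydroxymethyl)ethyl gives a 1.2-fold lower number from compound 2 to compound 3 (0.07 log units; within the scatter) and leaves the number level, and hydroxy in place of hydrogen on the chain gives a 1.0-fold higher number from compound 1 to compound 3 (0.01 log units; within the scatter) with the same outcome. So at this position on an oxygen on an aromatic ring, neither removing the ring of cyclopentyl nor bringing in a hydrogen-bond donor moved the number beyond the scatter. No measurement in hand gives a reason for this.

As far as these compounds go, whether an amine or a carboxylic acid at this place would shift the number remains open. From the compounds shown here alone, the opposite stereocentre of 1-(hydroxymethyl)ethyl also remains open.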